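Chloro to Fluoro on the Benzyl Ring: an Expected Step

A few compounds are considered here, and "the series" means these few. Any claim that something is new, unique, unknown or untested is made for them only; others in the source may bear on it.

Measured in a functional assay on FM3A cells (Mus musculus) for cytotoxicity, read by cell counting, with a stated time of 2 days; on this read-out higher numbers stand for weaker inhibition and lower numbers for stronger inhibition:
compound 1 `Nc1ccc(/C=C2\SC(=O)N(Cc3ccc(F)cc3)C2=O)cc1` gives 36000 nM
compound 2 `Nc1ccc(/C=C2\SC(=O)N(Cc3ccc(Cl)cc3)C2=O)cc1` gives 60000 nM
compound 3 `C=C(Br)C(=O)Nc1ccc(/C=C2\SC(=O)N(Cc3cccc(Cl)c3)C2=O)cc1` gives 6100 nM

Compound 1 and compound 2 share one core and differ in a single spot: fluoro in place of chloro on an aromatic carbon. That swap made a 1.7-fold lower number from compound 2 to compound 1 (0.22 log units; within the scatter). Compound 3 stands on a different core, and the difference between the two cores is not broken down here; its value is the lowest of the three, with both other numbers beyond the scatter above it.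

Compound 4 `C=C(Br)C(=O)Nc1ccc(/C=C2\SC(=O)N(Cc3cccc(F)c3)C2=O)cc1` has not yet been measured. It differs from compound 3 by fluoro in place of chloro on an aromatic carbon. In compound 1 and compound 2 the halogen sits para to a large group, whereas in compound 3 and compound 4 it sits meta to a large group, so this is the same kind of change, not the same one.

The expected step is a 1.4-fold lower number from compound 3 to compound 4 (0.13 log units; within the scatter), because the same change made a 1.7-fold lower number from compound 2 to compound 1 (0.22 log units; within the scatter) and nothing in the data points to a larger effect.

Compound 4 is therefore expected to give 4500 nM in this assay, estimated to fall between 2000 nM and 12000 nM.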

Compound 4, half-maximal inhibitory concentration: 4000 nM
Compound 4: the middle estimate sits 1.1-fold (0.05 log units) above what was measured; low and high end bracket the measured number.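

Replacing the 3-chlorobenzyl group with a 3-fluorobenzyl group gave a 1.5-fold lower number from compound 3 to compound 4 (0.18 log units; within the scatter) in this assay. Set beside the earlier chloro-to-fluoro swap, this step shows that the change behaved alike on both cores: the same change on two cores in this assay, a 1.7-fold lower number (0.22 log units; within the scatter) from compound 2 to compound 1 and a 1.5-fold lower number (0.18 log units; within the scatter) from compound 3 to compound 4, 1.1-fold (0.04 log units) apart, within the scatter of two such steps Since each step lies within the scatter, this agreement shows only that the swap made no clear difference on either core; it does not show that fluoro truly beats chloro, and two pairs in a single assay cannot establish a general rule for the series.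

The compounds shown leave open whether a different group on the same aromatic carbon, such as a methoxy group or a carboxylic acid, would shift the number beyond the scatter. They also leave open whether the chloro-to-fluoro swap would stay this small on other cores.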